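The compounds below may be only part of what the source reports. "The series", "measured", "known", "first", "only" and "open" are said of these compounds alone.

Compound 1, `COCCOC(=O)N1CCC(Oc2ncnc3c2CCN3c2ccc(S(C)(=O)=O)cc2F)CC1`, gives 316 nM in a functional assay on CHO-K1 cells for agonist activity at Glucose-dependent insulinotropic receptor (Homo sapiens), read by a luciferase reporter, with a stated time of 5 h; a lower number here means that less compound is needed, a higher number that more compound is needed for the effect. Compound 2, `CCSC(=O)N1CCC(Oc2ncnc3c2CCN3c2ccc(S(C)(=O)=O)cc2F)CC1`, gives 31.6 nM in this assay.

Compound 2 holds the lower of the two numbers; the gap between them is a 10-fold lower number from compound 1 to compound 2 (1.00 log units; beyond the scatter). Compound 3, `CS(=O)(=O)c1ccc(N2CCc3c(OC4CCN(C5=NCCCN5)CC4)ncnc32)c(F)c1`, is not yet measured and differs from compound 2 by a group of 6 heavy atoms (4 carbon, 2 nitrogen; one six-membered non-aromatic ring with 2 hetero atoms) in place of a group of 5 heavy atoms (3 carbon, 1 oxygen, 1 sulfur; no ring), on an amine nitrogen in a ring. Among the compounds with values here, the one measured step only swapped the group on the carbonyl carbon and kept the carbonyl, so it bears weakly on removing it; no step of this kind has been measured. Compound 3 is therefore expected at 100 nM in this assay, within 10 nM to 1000 nM. For compound 3 this means an expected 3.2-fold higher number from compound 2 to compound 3 (0.50 log units; beyond the scatter).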

Compound 3, half-maximal effective concentration: 2000 nM
Beside the measured number, compound 3's estimate is 20-fold (1.30 log units) below it; the whole stated range lies below it.
By their numbers in this assay, from the lowest: compound 2; then compound 1; then compound 3.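

Compound 1 and compound 2 both carry a carbonyl on the amine nitrogen in the ring, and compound 3 shows what happens when a non-carbonyl ring with two nitrogens takes its place: the number rises in both comparisons, with a 63-fold higher number from compound 2 to compound 3 (1.80 log units; beyond the scatter) and a 6.3-fold higher number from compound 1 to compound 3 (0.80 log units; beyond the scatter) in this assay. The size of the rise depends on the group replaced, and nothing available here accounts for the loss. The compounds shown leave open whether losing the carbonyl or adding the new ring matters more, a question that a plain ethyl group or an acetyl group on that nitrogen could help separate.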